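This account rests on a few compounds, and the source may have more. Where it says the series, first, only, none or still open, it means among the compounds named here.

The shared core is carried by three measured compounds. Compound 1 `O=C(NO)c1coc(-c2ccc(F)cc2)n1` gives 110 nM in an assay on isolated protein for inhibition of protein deacetylase HDAC6 (Homo sapiens), read by fluorescence, with a stated time of 90 min; on this read-out lower numbers stand for stronger inhibition and higher numbers for weaker inhibition. Compound 2 `O=C(NO)c1coc(-c2ccc3ccccc3c2)n1` gives 89 nM in this assay. Compound 3 `O=C(NO)c1noc(-c2ccccc2)n1` gives 112 nM in this assay; this number lies within the scatter of the numbers of compound 1 and of compound 2, so the three compounds cannot be told apart on what has been measured.

Compound 4 `O=C(NO)c1noc(-c2ccc(-c3ccccc3)cc2)n1` differs from compound 3 in one place: phenyl in place of hydrogen on an aromatic carbon. Going by the values given here, no measured pair shows this exact change, so its size has to be judged from what the three compounds show. Compound 1 gives 110 nM, and compound 2, which carries a larger aryl group, gives 89 nM; the difference between the two stays within the scatter. On that basis the step from compound 3 to compound 4 is expected to be small, in either direction, and most likely not beyond the scatter. Compound 4 is therefore expected to give about 85 nM in this assay, with a range from 35 nM to 220 nM. The step of a 1.3-fold lower number from compound 3 to compound 4 (0.12 log units; within the scatter) that this estimate means is expected to remain within the scatter.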

Compound 4, half-maximal inhibitory concentration: 1310 nM
Beside the measured number, compound 4's estimate is 15-fold (1.19 log units) below it; measured number above the stated range.
By their numbers in this assay, from the lowest: compounds 2, 1 and 3 (each within the scatter of the next); then compound 4.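

In this assay, phenyl in place of hydrogen on an aromatic carbon, para to a group of 9 heavy atoms, brings a 12-fold higher number from compound 3 to compound 4 (1.07 log units; beyond the scatter). Going by these compounds alone, this position therefore does not take this added phenyl without a loss of inhibition, which the earlier compounds could not show: they lie within the scatter of one another, and no two of them differ in one place. Nothing at hand bears on the reason for this step.

The compounds shown leave open whether a methyl or methoxy group in the same place would keep the number close to that of compound 3, or whether the loss comes only with a whole phenyl ring. They also leave open whether an amine or a carboxylic acid on the added phenyl would change the result.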